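Cyclohexyl to 2-cyclohexylethyl on compound 1

The source may hold more compounds than are shown below. What is called first, only, known or untested is meant among the compounds shown, and "the series" means these compounds.

In an ADME assay on P388D1 cells (Mus musculus) for cytotoxicity, read by fluorescence and resazurin assay, with a stated time of 72 h (on this read-out higher numbers stand for weaker inhibition and lower numbers for stronger inhibition), compound 1 (`O=C(c1cnc(NC(=O)C2CCCCC2)s1)c1cccc2ccccc12`) reads > 40000 nM, which is a limit and not a number. For compound 2 (`O=C(Nc1ncc(Cc2cc3sccc3s2)s1)C1CCCCC1`) the entry is "not determined" (no result reported). Within the data shown here, the only evidence so far is the limit of > 40000 nM in this assay, at which 1 of the 2 values shown sits.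

Compound 3 (`O=C(CCC1CCCCC1)Nc1ncc(C(=O)c2cccc3ccccc23)s1`) has 2-cyclohexylethyl in place of cyclohexyl on a carbonyl carbon. No measured step sizes this change, so no shift beyond the scatter is expected in this assay. The expected step is an at least 1.3-fold lower number from compound 1 to compound 3 (0.12 log units; that floor lies within the scatter). Compound 3 is estimated at 30000 nM, with an expected range of 10000 nM to 40000 nM.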

Compound 3, half-maximal inhibitory concentration: > 40000 nM
Compound 3: only a limit was reported; the forecaster's own chance of this, stated with the estimate: 60%; middle value at least 1.3-fold (0.12 log units) away from the limit.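

Compound 1 and compound 3 both read as limits in this assay, so no step can be read between them. From the compounds shown here alone, whether 2-cyclohexylethyl in place of cyclohexyl on a carbonyl carbon shifts this read-out at all remains open.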